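Replacing a Methyl on Oxygen: Compound 3 to Compound 4

The source may report more compounds than this note shows. Statements on the series, on what has been measured and on what is new or still open speak of the compounds shown alone.

Measured so far:
Compound 1, `COc1cc(C)cc(-c2nn(CC#N)cc2-c2ccc(-c3cccc(C(C)=O)c3)nc2)c1`: 1730 nM
Compound 2, `Cc1cc(O)cc(-c2nn(CC#N)cc2-c2ccnc(-c3ccc(Oc4ccccc4)cc3)c2)c1`: 3380 nM
Compound 3, `COc1cc(C)cc(-c2nn(CC#N)cc2-c2ccnc(-c3ccc(N(C)C)cc3)c2)c1`: 259 nM

All three were tested in a functional assay on SF-539 cells (Homo sapiens) for inhibition, read by sulforhodamine B assay, with a stated time of 48 h; a lower number here means a stronger inhibitor of growth, a higher number a weaker inhibitor of growth. Compound 3 gives the lowest number of the three, at 259 nM. The nearest to it is compound 1 with 1730 nM, a gap beyond the usual scatter, and the furthest is compound 2 with 3380 nM, also beyond the scatter. Compound 3 is therefore the strongest growth inhibitor among the measured compounds.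

Compound 4, `Cc1cc(O)cc(-c2nn(CC#N)cc2-c2ccnc(-c3ccc(N(C)C)cc3)c2)c1`, has not yet been measured. It differs from compound 3 in one place: hydrogen in place of methyl on an oxygen on an aromatic ring. Within the data shown here, no measured pair shows this same change on its own, so its effect here is unknown. Compound 2 carries the hydroxy group and gives the highest number, but it also differs elsewhere, so that comparison settles nothing. A small step is expected, possibly a slight weakening, of size a 1.5-fold higher number from compound 3 to compound 4 (0.19 log units; within the scatter). Compound 4 is estimated at 400 nM, within a range from 120 nM to 1300 nM.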

Compound 4, concentration for 50% growth inhibition: 2120 nM
Estimate against measurement, compound 4: 5.3-fold (0.72 log units) below; the measured number lies above the stated range.
By their numbers in this assay, from the lowest: compound 3; then compounds 1, 4 and 2 (each within the scatter of the next).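

In this assay the methyl on this oxygen counts for much: going from methoxy to hydroxy gives an 8.2-fold higher number from compound 3 to compound 4 (0.91 log units; beyond the scatter) and lies beyond the scatter, so one small change at this position moves the number clearly when the dimethylamino group is present. With hydroxy held fixed, dimethylamino in place of phenoxy gives a 1.6-fold lower number from compound 2 to compound 4 (0.20 log units; within the scatter) and stays within the scatter, so these two groups cannot be told apart in that setting. No measurement at hand explains why the methyl matters.

From the compounds shown here alone, it remains open whether methoxy to hydroxy has the same effect when phenoxy is present. Going by these compounds, it is also open whether a longer chain on the oxygen, such as ethoxy, or an amine in place of the hydroxy would match compound 3 or fall back towards compound 4.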